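The source may hold more compounds than are shown below. What is called first, only, known or untested is meant among the compounds shown, and "the series" means these compounds.

Measured compounds, with growth inhibition values in a functional assay on NCI-H23 cells (Homo sapiens) for antiproliferative activity, read by sulforhodamine B assay; a lower number here means a stronger inhibitor of growth, a higher number a weaker inhibitor of growth:

compound 1 `CC1(C)CC(=O)c2s/c(=N/c3ccc(Cl)cc3)oc2C1` — 11600 nM
compound 2 `CC1CC(=O)c2s/c(=N/c3ccc(Cl)cc3)oc2C1` — 13500 nM
compound 3 `CC1(C)CC(=O)c2s/c(=N/c3c(Cl)cc(Cl)cc3Cl)oc2C1` — > 30000 nM, which is a limit of this assay and not a number

Compound 1 and compound 2 share a core and differ in one place: hydrogen in place of methyl on a saturated ring carbon. That step, a 1.2-fold higher number from compound 1 to compound 2 (0.07 log units; within the scatter), is a small one. Both compounds sit in the same part of the range in this assay.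

Compound 3 carries a different core. How the core of compound 3 differs from that of compound 1 is not broken down here. For compound 3 only a limit of this assay is known, (the limit of > 30000 nM in this assay, at which 1 of the 3 values shown sits), so no number stands against it.

Compound 4 `CC1CC(=O)c2s/c(=N/c3c(Cl)cc(Cl)cc3Cl)oc2C1` is not yet measured in this assay. It stands to compound 3 as compound 2 stands to compound 1: hydrogen in place of methyl on a saturated ring carbon. The place of the change is the same in both pairs, so the change is the same, not merely the same kind.

Expectation for compound 4: the only measured instance of this change, a 1.2-fold higher number from compound 1 to compound 2 (0.07 log units; within the scatter), stayed within the scatter, so the step that the limit leaves unreadable from compound 3 to compound 4 is expected to be small as well. Since compound 3 is known only as a limit, compound 4 is expected to come out near or beyond that limit too, and a reading of 45000 nM is estimated, with a range from 25000 nM to 100000 nM, most likely reported again only as a limit.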

Compound 4, concentration for 50% growth inhibition: > 30000 nM
Compound 4: a limit, no number (the forecaster's own chance of this, stated with the estimate: 85%); the middle value lies beyond the limit too.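

No step can be read between compound 3 and compound 4, since both sit at a limit of this assay and not at a number: the limit of > 30000 nM in this assay, at which 2 of the 4 values shown sit.

The compounds shown leave open whether hydrogen in place of methyl on a saturated ring carbon changes growth inhibition at all with the core of compound 3, and how far past the limit either compound lies.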